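The source may report more compounds than this note shows. Statements on the series, on what has been measured and on what is new or still open speak of the compounds shown alone.

Compound 1 `CC(C)[C@H](C(=O)Nc1ccccn1)c1ccc(Cl)cc1` gives the lower of the two numbers measured in a functional assay on CHO cells for agonist activity at Free fatty acid receptor 2 (Homo sapiens), read by cAMP accumulation (a lower number here means a stronger inhibitor, a higher number a weaker inhibitor), at 1400 nM. Going by the values given here, compound 2 `CC(C)C(C(=O)Nc1ncccn1)c1ccc(Cl)cc1` gives 53000 nM in this assay, a far higher number than that of compound 1, but it differs from compound 1 in more than one place, so the two values show no single step. Compound 3 `CC(C)[C@H](C(=O)NC1=NC(=O)CS1)c1ccc(Cl)cc1` carries a group of 6 heavy atoms (3 carbon, 1 nitrogen, 1 oxygen, 1 sulfur; one five-membered non-aromatic ring with 2 hetero atoms) in place of a group of 6 heavy atoms (5 carbon, 1 nitrogen; one six-membered aromatic ring with 1 hetero atom), on an amide-type nitrogen. Among the compounds with values here, no measured pair shows this exchange, so the step from compound 1 is a guess; he expects it to weaken the compound beyond the scatter, a 2.9-fold higher number from compound 1 to compound 3 (0.46 log units; beyond the scatter), and estimates compound 3 at 4000 nM, within 800 nM to 25000 nM.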

Compound 3, half-maximal inhibitory concentration: 20000 nM
Compound 3: the middle estimate sits 5.0-fold (0.70 log units) below what was measured, within the range that was stated.
By their numbers in this assay, from the lowest: compound 1; then compound 3; then compound 2.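

Exchanging the pyridin-2-yl group on the amide-type nitrogen for the five-membered non-aromatic ring with 2 hetero atoms gives, in this assay, a 14-fold higher number from compound 1 to compound 3 (1.15 log units; beyond the scatter). Going by these compounds alone, this is the first single-place step in the set, and it shows that the number responds strongly to the group at this position, even though both groups hold 6 heavy atoms. Nothing available here accounts for the size of this step. The compounds shown leave open whether another group on this nitrogen, such as a phenyl ring or a thiazol-2-yl ring, would give a number lower than that of compound 1.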